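The source may report more compounds than this note shows. Statements on the series, on what has been measured and on what is new or still open speak of the compounds shown alone.

Measured in a functional assay (Cavia porcellus) for antagonist activity at Serotonin 3 (5-HT3) receptor (Homo sapiens); a lower number here means a stronger inhibitor, a higher number a weaker inhibitor:
compound 1 `Cc1[nH]cnc1CN1CCN(c2cccc(Br)c2)C1=O` gives 10.4 nM
compound 2 `Cc1[nH]cnc1CN1CCN(c2ccccc2)C1=O` gives 26.9 nM
compound 3 `CSc1cccc(N2CCN(Cc3nc[nH]c3C)C2=O)c1` gives 120 nM

Compound 3 holds the highest number of the three in this assay, with compound 2 nearest below it and compound 1 furthest. Compound 4 `Cc1[nH]cnc1CN1CCN(c2cccc(F)c2)C1=O` differs from compound 3 by fluoro in place of methylsulfanyl on an aromatic carbon. Going by the values given here, two measured steps bear on this: a 12-fold higher number from compound 1 to compound 3 (1.06 log units; beyond the scatter) and a 4.5-fold higher number from compound 2 to compound 3 (0.65 log units; beyond the scatter) both show the methylsulfanyl group carrying the highest number of the series, while a 2.6-fold higher number from compound 1 to compound 2 (0.41 log units; beyond the scatter) shows bromo giving a lower number than hydrogen on that aromatic carbon. Fluoro is therefore expected to land between compounds 1 and 2, a large drop from compound 3, estimated as a 6.0-fold lower number from compound 3 to compound 4 (0.78 log units; beyond the scatter). For compound 4 the expected value is 20 nM, within a range of 8 nM to 50 nM.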

Compound 4, antagonist equilibrium constant: 88.3 nM
Compound 4: the middle estimate sits 4.4-fold (0.64 log units) below what was measured, outside the stated range (above it).
By their numbers in this assay, from the lowest: compound 1; then compound 2; then compounds 4 and 3 (each within the scatter of the next).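

Fluoro and methylsulfanyl cannot be told apart on this aromatic carbon (a 1.4-fold lower number from compound 3 to compound 4 (0.13 log units; within the scatter)), although the change removes a heavy atom and the sulfur. Fluoro also gives a higher number than hydrogen (a 3.3-fold higher number from compound 2 to compound 4 (0.52 log units; beyond the scatter)) and than bromo (an 8.5-fold higher number from compound 1 to compound 4 (0.93 log units; beyond the scatter)), so among the groups shown only bromo gives a lower number than hydrogen. No measurement at hand accounts for this.

Going by these compounds, whether chloro, methoxy or an amine here would follow bromo or fluoro remains open.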